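Working notes: from compound 2 to compound 3

A few compounds are considered here, and "the series" means these few. Any claim that something is new, unique, unknown or untested is made for them only; others in the source may bear on it.

Compound 1 `CC(C)(C)c1[nH]cnc1/C=c1\[nH]c(=O)/c(=C/c2cccc(C(=O)N3CCC3)c2)[nH]c1=O`: 4.23 ug/mL
Compound 2 `CC(C)(C)c1[nH]cnc1/C=c1\[nH]c(=O)/c(=C/c2cccc(C(=O)N3CCCCC3)c2)[nH]c1=O`: < 0.1 ug/mL (a limit)

In a physicochemical assay for solubility, read by HPLC, with a stated time of 24 h (on this read-out higher numbers stand for higher solubility and lower numbers for lower solubility), compound 2 gives < 0.1 ug/mL, which is a limit and not a number. Compound 3 `O=C(c1cccc(/C=c2\[nH]c(=O)/c(=C/c3ccccn3)[nH]c2=O)c1)N1CCCCC1` carries pyridin-2-yl in place of 5-(tert-butyl)-1H-imidazol-4-yl on a double-bonded chain carbon bound to an aromatic carbon. Going by the values given here, the only measured step, an at least 42-fold lower number from compound 1 to compound 2 (1.62 log units; beyond the scatter), is large but lies on a carbonyl carbon, and piperidin-1-yl stays in compound 3, so it gives no size for this change. Only a small upward move is expected in this assay, estimated as an at least 2.5-fold higher number from compound 2 to compound 3 (0.39 log units; beyond the scatter). For compound 3 the estimated value is 0.25 ug/mL, with an expected range of 0.05 ug/mL to 1.5 ug/mL.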

Compound 3, solubility: < 0.1 ug/mL
Compound 3 gave a limit, no number; the forecaster's own chance of this, stated with the estimate: 40%; at least 2.5-fold (0.39 log units) between middle value and limit.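

No new step can be read from compound 2 to compound 3 in this assay, since each gives a limit and not a number: the limit of < 0.1 ug/mL in this assay, at which 2 of the 3 values shown sit.

The compounds shown leave open whether pyridin-2-yl in place of 5-(tert-butyl)-1H-imidazol-4-yl moves the read-out at all.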